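A methoxy swap on the benzyl arm of a weak inhibitor

This account rests on a few compounds, and the source may have more. Where it says the series, first, only, none or still open, it means among the compounds named here.

Compound 1 `O=c1ccoc2cc(OCc3cn(Cc4cccc(Br)c4)nn3)ccc12` sits at a limit of the assay: in a functional assay on SW480 cells (Homo sapiens) for cytotoxicity, read by MTT assay, with a stated time of 48 h (a lower number here means a stronger inhibitor, a higher number a weaker inhibitor), compound 1 gives > 100000 nM, a limit rather than a number. Compound 2 `O=c1ccoc2cc(OCc3cn(Cc4cccc([N+](=O)[O-])c4)nn3)ccc12` sits at the same limit, giving > 100000 nM in this assay. Compound 3 `O=c1ccoc2cc(OCc3cn(Cc4ccccc4Cl)nn3)ccc12` gives 23500 nM in this assay, so the steps of an at least 4.2-fold lower number from compound 1 to compound 3 (0.62 log units; beyond the scatter) and an at least 4.2-fold lower number from compound 2 to compound 3 (0.62 log units; beyond the scatter) both point toward stronger inhibition with the 2-chlorophenyl. Compound 4 `COc1ccc(Cn2cc(COc3ccc4c(=O)ccoc4c3)nn2)cc1` differs from compound 1 by 4-methoxyphenyl in place of 3-bromophenyl on a saturated chain carbon bound to an aromatic nitrogen. Within the data shown here, no measured step involves the 4-methoxyphenyl; the readable steps concern only the 2-chlorophenyl, and the shared limit of > 100000 nM in this assay, at which 2 of the 3 values shown sit, leaves the step from compound 1 to compound 2 unreadable. Compound 4 is therefore expected to remain near the limit, with an estimated step of a number no higher from compound 1 to compound 4 (the limit leaves the size open). The estimate for compound 4 is 100000 nM, ranging from 30000 nM to 300000 nM.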

Compound 4, half-maximal inhibitory concentration: 20400 nM
The estimate for compound 4 lay 4.9-fold (0.69 log units) above the measured number, outside the stated range (below it).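

In this assay, a second benzyl arm now comes off the limit: an at least 4.9-fold lower number from compound 1 to compound 4 (0.69 log units; beyond the scatter) and an at least 4.9-fold lower number from compound 2 to compound 4 (0.69 log units; beyond the scatter) show that the 2-chlorophenyl is not alone in doing so. Set against that group, the 4-methoxyphenyl gives a 1.2-fold lower number from compound 3 to compound 4 (0.06 log units; within the scatter) and so does not separate from it. Both steps from the limit give only a minimum size: the limit of > 100000 nM in this assay, at which 2 of the 4 values shown sit.

Going by these compounds, whether an amine or a carboxylic acid on this phenyl ring would keep this level remains open. So does the effect of a longer chain in place of the benzyl carbon.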